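The source may report more compounds than this note shows. Statements on the series, on what has been measured and on what is new or still open speak of the compounds shown alone.

Measured compounds:
compound 1 `COc1ccc(CNc2cc(Oc3ccc(NC(=O)Nc4ccc(C)c(C(F)(F)F)c4)cc3)ncn2)cc1`: in a functional assay on BaF3 cells (Mus musculus) for inhibition, read by CCK-8 assay, with a stated time of 72 h (on this read-out lower numbers stand for stronger inhibition of growth and higher numbers for weaker inhibition of growth), compound 1 gives 1000 nM
compound 2 `CC(=O)Nc1cc(Oc2ccc(NC(=O)Nc3ccc(C)c(C(F)(F)F)c3)cc2)ncn1`: in this assay compound 2 gives 3230 nM

Among the measured compounds shown here, compound 2 stands at the highest of the two numbers; its only neighbour is compound 1, and the single measured step is a 3.2-fold higher number from compound 1 to compound 2 (0.51 log units; beyond the scatter).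

Compound 3 `Cc1ccc(NC(=O)Nc2ccc(Oc3cc(NCc4ccccc4)ncn3)cc2)cc1C(F)(F)F` differs from compound 2 in one place: benzyl in place of acetyl on a nitrogen on an aromatic ring. For the measured compounds named here, the benzyl group entering here is the 4-methoxybenzyl group of compound 1 without its methoxy substituent, so the change largely reverses the one measured step. That step, a 3.2-fold higher number from compound 1 to compound 2 (0.51 log units; beyond the scatter), was modest but beyond the scatter; run backwards, a step of similar size in the opposite direction is expected, with the number for compound 3 falling towards that of compound 1.

The expected step is therefore a 2.9-fold lower number from compound 2 to compound 3 (0.47 log units; beyond the scatter). Compound 3 is estimated at 1100 nM, within a range of 400 nM to 3000 nM.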

Compound 3, concentration for 50% growth inhibition: 3010 nM
Estimate against measurement, compound 3: 2.7-fold (0.44 log units) below; the whole stated range lies below it.
By their numbers in this assay, from the lowest: compound 1; then compounds 3 and 2 (each within the scatter of the next).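

In this assay, acetamido to benzylamino on the nitrogen makes no readable difference on its own: a 1.1-fold lower number from compound 2 to compound 3 (0.03 log units; within the scatter). The methoxy substituent now carries the measured difference within this trio, with a 3.0-fold higher number from compound 1 to compound 3 (0.48 log units; beyond the scatter), so the benzyl group alone does not reproduce the stronger growth inhibition of compound 1, and the earlier step from compound 1 to compound 2 cannot be read as a simple acetyl-against-benzyl effect. No supporting data explain why the methoxy group matters here.

Still open, from the compounds shown here alone, is whether the methoxy group is needed as such, or whether an ethoxy group, a hydroxyl group or a chlorine atom on the same benzyl ring would serve equally. Also open, going by these compounds, is how a longer chain such as phenethyl, or a basic amine such as a dimethylaminoethyl group, would behave on this nitrogen.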